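Nitro on the Furan Ring in Two Related Cores

This account rests on a few compounds, and the source may have more. Where it says the series, first, only, none or still open, it means among the compounds named here.

Of the compounds shown here, three have been tested in a functional assay on the whole organism (strain Wistar Albino) for inhibition, with Rattus norvegicus as the target, read by paw edema, with a stated time of 1 h, at a dose of 20 mg/kg; a lower number here means less inhibition, a higher number more inhibition at the dose given (going by the name of the read-out). Compound 1 `COc1ccc(Cl)c(-c2nnc3n2NC(c2ccco2)S3)c1` gives 13.9% in this assay. Compound 3 `COc1ccc(Cl)c(-c2nnc3n2NC(c2ccc([N+](=O)[O-])o2)S3)c1` differs from compound 1 by nitro in place of hydrogen on an aromatic carbon. In this assay compound 3 gives 15.6%, so the step is a number 1.7 percentage points higher from compound 1 to compound 3 (within the scatter). Compound 2 `COc1ccc(Cc2nnc3n2NC(c2ccco2)S3)cc1OC` has a different core; how the two cores differ is not broken down here. In this assay compound 2 gives 12%, a number that sits within the scatter of both compound 1 and compound 3.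

Compound 4 `COc1ccc(Cc2nnc3n2NC(c2ccc([N+](=O)[O-])o2)S3)cc1OC` has not yet been measured. It differs from compound 2 by nitro in place of hydrogen on an aromatic carbon, the same change that leads from compound 1 to compound 3. Because that change gave a number 1.7 percentage points higher from compound 1 to compound 3 (within the scatter), compound 4 is expected to move only a number 1.5 percentage points higher from compound 2 to compound 4 (within the scatter) from compound 2 in this assay. The estimate for compound 4 in this assay is therefore 13.5%, with a range from 5% to 22% that reflects the scatter of single-dose readings of this kind.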

Compound 4, a percentage reported as inhibition, in the whole organism at one dose (the size of the read-out at that dose, not a potency): 14.5%
For compound 4 the middle estimate is 1 percentage points below the measured one; measured number inside the range.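

In this assay, the nitro group placed on the furan ring gives a number 2.5 percentage points higher from compound 2 to compound 4 (within the scatter). Set beside the earlier case, the same change looks alike on both cores: the same change on two cores in this assay, a number 1.7 percentage points higher (within the scatter) from compound 1 to compound 3 and a number 2.5 percentage points higher (within the scatter) from compound 2 to compound 4, 0.8 percentage points apart, within the scatter of two such steps This shows that, on these two cores, going from furan-2-yl to 5-nitrofuran-2-yl leaves the reading within the usual spread of repeated measurements; it does not show that nitro raises inhibition, and with so small a step on each core, the agreement is only a match between two steps too small to tell from scatter, not proof that a real effect carries over from one core to another.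

The compounds shown leave open whether a different group at this place on the furan ring, such as an amine or a carboxylic acid, would move the reading beyond the scatter. They also leave open whether the nitro change would behave the same way on any other core, or at another dose or time.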